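The source may report more compounds than this note shows. Statements on the series, on what has been measured and on what is new or still open speak of the compounds shown alone.

Of the compounds shown here, three on the shared core have been measured. In a functional assay on NB-4 cells (Homo sapiens) for cytotoxicity, read by CCK-8 assay, with a stated time of 24 h (on this read-out lower numbers stand for stronger inhibition and higher numbers for weaker inhibition), compound 1 (`C=CC(=O)N1C(=O)CC(c2ccc(OC)cc2)Sc2ccccc21`) gives 32900 nM and compound 2 (`C=CC(=O)N1C(=O)CC(c2ccc(Cl)cc2)Sc2ccccc21`) gives 22600 nM while compound 3 (`C=CC(=O)N1C(=O)CC(c2ccccc2)Sc2ccccc21`) gives 35500 nM on the same read-out. Compound 3 thus lies within the scatter of both others, and the three values are not separated. Compound 4 (`C=CC(=O)N1C(=O)CC(c2ccc(C#N)cc2)Sc2ccccc21`) differs from compound 3 by cyano in place of hydrogen on an aromatic carbon, para to a large group (cyano in place of hydrogen on an aromatic carbon). The measured steps that bear on this change are exchanges among hydrogen, methoxy and chloro at that place. They are a 1.1-fold higher number from compound 1 to compound 3 (0.03 log units; within the scatter) and a 1.6-fold higher number from compound 2 to compound 3 (0.20 log units; within the scatter) and a 1.5-fold lower number from compound 1 to compound 2 (0.16 log units; within the scatter) and all three stay within the scatter. Going by the values given here, no measured compound carries cyano, so the evidence is indirect. No change beyond the scatter is therefore expected in this assay for this exchange. The expected size is a 1.3-fold lower number from compound 3 to compound 4 (0.10 log units; within the scatter) and no firm direction is implied. The estimated value for compound 4 is 28000 nM with an expected range from 15000 nM to 50000 nM on this read-out.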

Compound 4, half-maximal inhibitory concentration: 62400 nM
Compound 4: the middle estimate sits 2.2-fold (0.35 log units) below what was measured; the whole stated range lies below it.
By their numbers in this assay, from the lowest: compounds 2, 1, 3 and 4 (each within the scatter of the next, the first and the last beyond it).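

In this assay, going by these compounds alone, cyano gives the first step at this position that leaves the scatter, a 2.8-fold higher number from compound 2 to compound 4 (0.44 log units; beyond the scatter), a modest gap that the exchanges among hydrogen, methoxy and chloro had not produced. This separation is confined to the exchange with chloro, as the other two steps, a 1.8-fold higher number from compound 3 to compound 4 (0.24 log units; within the scatter) and a 1.9-fold higher number from compound 1 to compound 4 (0.28 log units; within the scatter), stay within the scatter, so cyano is not set apart from hydrogen or methoxy. No measurement is available that would explain the gap between the chloro and cyano compounds.

On these data alone, whether an amine, a carboxylic acid or a longer chain on the aromatic carbon would move the number further than cyano does remains open. The compounds shown also leave open whether the gap between chloro and cyano would hold on another core.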